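The source may report more compounds than this note shows. Statements on the series, on what has been measured and on what is new or still open speak of the compounds shown alone.

In a functional assay on HL-60 cells (Homo sapiens) for cytotoxicity, read by WST assay, with a stated time of 48 h (a higher number here means a weaker inhibitor, a lower number a stronger inhibitor), compound 1 `C=CC[C@H]1C[C@@H]([C@@H](O)c2ccccc2)CO[C@@H]1c1ccccc1` gives 36000 nM and compound 2 `O=[N+]([O-])c1ccc(/C=C/C[C@H]2C[C@@H]([C@@H](O)c3ccccc3)CO[C@@H]2c2ccccc2)cc1` gives 4880 nM as the lower of the two numbers. That gap lies beyond the usual scatter, which makes compound 2 the stronger inhibitor of this pair. Compound 3 `O[C@@H](c1ccccc1)[C@H]1CO[C@H](c2ccccc2)[C@@H](C/C=C/c2cccnc2)C1` has not yet been measured. It differs from compound 2 by pyridin-3-yl in place of 4-nitrophenyl on a double-bonded chain carbon bound to a double-bonded chain carbon with pyridin-3-yl in place of 4-nitrophenyl on a double-bonded chain carbon bound to a double-bonded chain carbon. For the measured compounds named here, no measured pair shows this swap on its own, so any forecast remains loose. Compound 3 keeps a six-membered aromatic ring on the chain, and it is expected to sit closer to compound 2 at 4880 nM than to compound 1 at 36000 nM on this scale. In this assay a modest weakening is expected, toward a higher number, with the estimated change a 2.0-fold higher number from compound 2 to compound 3 (0.31 log units; beyond the scatter) as the working figure. For compound 3 the estimate is 10000 nM within an expected range of 3500 nM to 30000 nM until the measurement is in.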

Compound 3, half-maximal inhibitory concentration: > 100000 nM
Compound 3: a limit, no number; the forecaster's own chance of this, stated with the estimate: 10%; middle value at least 10-fold (1.00 log units) away from the limit.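

For compound 3 the reading in this assay is a limit and not a number: the limit of > 100000 nM in this assay, at which 1 of the 3 values shown sits. Even so, this place on the chain proves highly sensitive to the aromatic group it carries: pyridin-3-yl in place of 4-nitrophenyl on a double-bonded chain carbon bound to a double-bonded chain carbon gives an at least 20-fold higher number from compound 2 to compound 3 (1.31 log units; beyond the scatter) and removes the advantage that compound 2 held over compound 1. The earlier pair could not show that an aromatic ring on this chain is no gain in itself, yet 2-(pyridin-3-yl)ethenyl in place of vinyl gives an at least 2.7-fold higher number from compound 1 to compound 3 (0.44 log units; beyond the scatter) and so leaves compound 3 behind compound 1 as well.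

The compounds shown do not separate the loss of the nitro group from the entry of the ring nitrogen, as both change in this single step. From the compounds shown here alone, how a plain phenyl, a 4-aminophenyl or a 4-carboxyphenyl group would read at this place on the same chain remains open, and these would show whether the weakening follows the ring nitrogen or the missing nitro group.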